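The compounds below may be only part of what the source reports. "The series", "measured", "known", "first", "only" and "open" are said of these compounds alone.

Measured in a functional assay on HL-60 cells (Homo sapiens) for antiproliferative activity, with a stated time of 72 h; a higher number here means a weaker inhibitor, a lower number a stronger inhibitor:
- compound 1 `COc1ccccc1CNc1ncnc2c1ncn2[C@@H]1O[C@H](CO)[C@@H](O)[C@H]1O`: 2300 nM
- compound 2 `COc1ccc(CNc2ncnc3c2ncn3[C@@H]2O[C@H](CO)[C@@H](O)[C@H]2O)c(OC)c1`: 39000 nM
- compound 3 `COc1cc(CNc2ncnc3c2ncn3[C@@H]2O[C@H](CO)[C@@H](O)[C@H]2O)cc(OC)c1`: 20200 nM

All three have the shared core and differ only in the methoxy groups on the phenyl group. Compound 3 sits clearly on the weaker side of compound 1, as shown by an 8.8-fold higher number from compound 1 to compound 3 (0.94 log units; beyond the scatter). It cannot be told apart from compound 2, given a 1.9-fold lower number from compound 2 to compound 3 (0.29 log units; within the scatter). The remaining measured step is a 17-fold higher number from compound 1 to compound 2 (1.23 log units; beyond the scatter), so both dimethoxyphenyl compounds give higher numbers than compound 1.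

Compound 4 `OC[C@H]1O[C@@H](n2cnc3c(NCc4ccc(F)c(Cl)c4)ncnc32)[C@H](O)[C@@H]1O` differs from compound 3 as follows: 3-chloro-4-fluorophenyl in place of 3,5-dimethoxyphenyl on a saturated chain carbon bound to a nitrogen on an aromatic ring. In words, 3-chloro-4-fluorophenyl stands in place of 3,5-dimethoxyphenyl on a saturated chain carbon bound to a nitrogen on an aromatic ring. Going by the values given here, no measured compound carries chlorine or fluorine, so the evidence is indirect. The nearest guide is an 8.8-fold higher number from compound 1 to compound 3 (0.94 log units; beyond the scatter), read in reverse, since moving away from the dimethoxyphenyl groups went with a lower number. A modest drop in this assay is therefore expected, though with wide uncertainty. The expected change is a 3.4-fold lower number from compound 3 to compound 4 (0.53 log units; beyond the scatter). For compound 4 the estimated value is 6000 nM, with an expected range of 1300 nM to 28000 nM.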

Compound 4, half-maximal inhibitory concentration: 3500 nM
For compound 4 the middle estimate is 1.7-fold (0.23 log units) above the measured one, and the stated range covers the measured number.
By their numbers in this assay, from the lowest: compounds 1 and 4 (each within the scatter of the next); then compounds 3 and 2 (each within the scatter of the next).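

In this assay, the 3-chloro-4-fluorophenyl group shows that this place on the saturated chain carbon bound to a nitrogen on an aromatic ring does not need a methoxy group to give a low number, with both dimethoxyphenyl compounds left well behind (first a 5.8-fold lower number from compound 3 to compound 4 (0.76 log units; beyond the scatter) and then an 11-fold lower number from compound 2 to compound 4 (1.05 log units; beyond the scatter)). Compound 4 cannot be told apart from compound 1 (a 1.5-fold higher number from compound 1 to compound 4 (0.18 log units; within the scatter)), so a phenyl group bearing chlorine and fluorine and one bearing a single methoxy group land at the same level. No measurement shown here offers a reason for these differences.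

On these data alone, whether the chlorine or the fluorine alone would do the same stays open, since the two enter together. Also open, as far as these compounds go, is what an amine or a carboxylic acid on the phenyl group, or a longer chain in place of the saturated chain carbon, would give.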